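Swapping hydroxymethyl for ethoxycarbonyl on compound 1

A few compounds are considered here, and "the series" means these few. Any claim that something is new, unique, unknown or untested is made for them only; others in the source may bear on it.

compound 1 `O=C(CCl)N1CCCC(n2nc(-c3ccc(Oc4ccccc4)cc3)cc2CO)C1`: 1100 nM
compound 2 `C=CC(=O)Nc1cccc(Cn2nc(-c3ccc(Oc4ccccc4)cc3)cc2C(=O)OCC)c1`: 8600 nM
compound 3 `C=CC(=O)Nc1ccc(Cn2nc(-c3ccc(Oc4ccccc4)cc3)cc2CO)cc1`: 7000 nM

In a functional assay on Maver1 cells (Homo sapiens) for inhibition, read by luminescence and CellTiter-Glo, with a stated time of 72 h (on this read-out lower numbers stand for stronger inhibition and higher numbers for weaker inhibition), compound 1 gives 1100 nM, the lowest of the three numbers, and its gaps to compound 2 and compound 3 both lie beyond the scatter. Compound 4 `CCOC(=O)c1cc(-c2ccc(Oc3ccccc3)cc2)nn1C1CCCN(C(=O)CCl)C1` keeps the core of compound 1 but carries ethoxycarbonyl in place of hydroxymethyl on an aromatic carbon. Within the data shown here, no measured pair isolates this change. Compound 2 carries ethoxycarbonyl and gives 8600 nM. Compound 3 carries hydroxymethyl and gives 7000 nM. These two values lie within the scatter of each other, but the two compounds also differ elsewhere, so they offer only weak guidance. A moderate step towards a higher number is therefore expected in this assay, although a step within the scatter remains possible. The estimated change is a 2.0-fold higher number from compound 1 to compound 4 (0.30 log units; within the scatter). For compound 4 the expected value is 2200 nM, with an estimated range of 800 nM to 7000 nM.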

Compound 4, half-maximal inhibitory concentration: 1200 nM
Beside the measured number, compound 4's estimate is 1.8-fold (0.26 log units) above it; low and high end bracket the measured number.
By their numbers in this assay, from the lowest: compounds 1 and 4 (each within the scatter of the next); then compounds 3 and 2 (each within the scatter of the next).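

In this assay, replacing hydroxymethyl with ethoxycarbonyl on this aromatic carbon of the core of compound 1 gives a 1.1-fold higher number from compound 1 to compound 4 (0.04 log units; within the scatter) and so stays within the scatter. This position therefore accepts the change from hydroxymethyl to ethoxycarbonyl, with its loss of the hydrogen-bond donor and its gain in heavy atoms, without a step beyond the scatter on this core, something compound 2 and compound 3 could not show since they also differ elsewhere. Nothing available gives a reason for this result. On these data alone, whether the step stays within the scatter with a carboxylic acid, an amine or a longer chain at this position remains open. As far as these compounds go, it is also open whether the same exchange would behave alike on the other parts of compound 2 or compound 3.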